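Phenyl for hydrogen at two places in a stability series

This account rests on a few compounds, and the source may have more. Where it says the series, first, only, none or still open, it means among the compounds named here.

Compound 1 `CC(C)(C)C1=C(C(=O)O)N2C(=O)[C@H](CO)[C@@H]2O1` serves as the parent. In an ADME assay, in phosphate buffer, at 28 degrees C, at pH 7.0 (on this read-out higher numbers stand for a longer-lived compound and lower numbers for a shorter-lived compound), compound 1 gives 2.4 h. Compound 2 `CC(C)(C)C1=C(C(=O)O)N2C(=O)[C@H]([C@H](O)c3ccccc3)[C@@H]2O1` carries the change phenyl in place of hydrogen on a saturated chain carbon bound to an oxygen on a saturated carbon and a saturated ring carbon and in this assay compound 2 gives 0.5 h; the measured step is a 4.8-fold lower number from compound 1 to compound 2 (0.68 log units; beyond the scatter). Compound 3 `CC(C)(C)C1=C(C(=O)O)N2C(=O)[C@H](CNS(C)(=O)=O)[C@H]2O1` has a different core; the difference between the two cores is not broken down here. In this assay compound 3 gives 2.2 h, which sits within the scatter of compound 1 and clearly above compound 2. Compound 4 `CC(C)(C)C1=C(C(=O)O)N2C(=O)[C@H](CNS(=O)(=O)Cc3ccccc3)[C@H]2O1` has not yet been measured; it differs from compound 3 by phenyl in place of hydrogen on a saturated chain carbon bound to a sulfonyl sulfur. This is the same kind of change as that from compound 1 to compound 2, though not the same: there the phenyl entered on a saturated chain carbon bound to an oxygen on a saturated carbon and a saturated ring carbon, here on a saturated chain carbon bound to a sulfonyl sulfur. Within the data shown here, the only guide to size is a 4.8-fold lower number from compound 1 to compound 2 (0.68 log units; beyond the scatter), taken at a different place, so the expected step is a 1.8-fold lower number from compound 3 to compound 4 (0.26 log units; within the scatter), a drop but a smaller one. Compound 4 is estimated at 1.2 h, expected to fall between 0.5 h and 2.6 h.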

Compound 4, half-life: 8.9 h
Compound 4: the middle estimate sits 7.4-fold (0.87 log units) below what was measured; measured number outside the range, above it.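

In this assay, phenyl in place of hydrogen on a saturated chain carbon bound to a sulfonyl sulfur gives a 4.0-fold higher number from compound 3 to compound 4 (0.61 log units; beyond the scatter), so the earlier drop is not reproduced in this second setting. The size and direction of the change therefore do not carry over from the core of compound 1 to the core of compound 3, and the two steps differ by more than scatter: the same change on two cores in this assay, a 4.8-fold lower number (0.68 log units; beyond the scatter) from compound 1 to compound 2 and a 4.0-fold higher number (0.61 log units; beyond the scatter) from compound 3 to compound 4, 19-fold (1.29 log units) apart, beyond the scatter of two such steps. This does not show what sets the direction, as the two pairs differ both in core and in the place where phenyl enters, and two pairs give no rule for any other core.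

As far as these compounds go, it remains open whether the higher number seen on going from methyl to benzyl persists with a longer chain ending in phenyl, or with an amine or a carboxylic acid in place of the phenyl. Also open, from the compounds shown here alone, is how phenyl for hydrogen would behave on the chain of compound 1 when that chain sits on the core of compound 3.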